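The source may hold more compounds than are shown below. What is called first, only, known or untested is meant among the compounds shown, and "the series" means these compounds.

Compounds measured in a functional assay on the whole organism (strain Wistar) for inhibition, with Rattus norvegicus as the target, read by paw edema, with stated times of 60 min and 2 h, at a dose of 100 mg/kg by the oral route; a higher number here means more inhibition at the dose given (going by the name of the read-out), a lower number less inhibition:

- Compound 1, `COc1cc2c(cc1OC)C(CC(N)=O)CC2`: 31%
- Compound 2, `CCN(CC)C(=O)CC1CCc2cc(OC)c(OC)cc21`: 40%
- Compound 3, `COc1cc2c(cc1OC)C(CC(=O)NC(C)(C)C)CC2`: 32%

All three compounds share one core and differ only in the group on the carbonyl carbon of the side chain. Compound 3 stands second highest of the three numbers in this assay; its nearest neighbour is compound 1, with a step of a number 1 percentage points higher from compound 1 to compound 3 (within the scatter), and its furthest is compound 2, with a step of a number 8 percentage points lower from compound 2 to compound 3 (within the scatter). The step of a number 9 percentage points higher from compound 1 to compound 2 (within the scatter) is likewise within the scatter, so no ordering among the three can be read from these numbers.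

Compound 4, `COc1cc2c(cc1OC)C(CC(=O)N1CCCC1)CC2`, has not been measured. It differs from compound 3 in one place: pyrrolidin-1-yl in place of (tert-butyl)amino on a carbonyl carbon

For the measured compounds named here, the step that bears on this change most directly is the one from the diethylamino compound to the tert-butylamino compound, a number 8 percentage points lower from compound 2 to compound 3 (within the scatter), since compound 4 again carries a group without an amide hydrogen on the carbonyl carbon. That step was within the scatter, and so were the others, so no step beyond the scatter is expected in this assay. Compound 4 is expected to give 37%, with a range from 25% to 49%, an estimated step of a number 5 percentage points higher from compound 3 to compound 4 (within the scatter).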

Compound 4, a percentage reported as inhibition, in the whole organism at one dose (the size of the read-out at that dose, not a potency): 20%
Estimate against measurement, compound 4: 17 percentage points above, outside the stated range (below it).
By their numbers in this assay, from the lowest: compound 4; then compounds 1, 3 and 2 (each within the scatter of the next).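

For the compounds shown here, with pyrrolidin-1-yl on the carbonyl carbon, this assay shows steps beyond the scatter for the first time: a number 12 percentage points lower from compound 3 to compound 4 (beyond the scatter), a number 20 percentage points lower from compound 2 to compound 4 (beyond the scatter), and a number 11 percentage points lower from compound 1 to compound 4 (beyond the scatter). Compound 2 also lacks an amide hydrogen, yet it stands apart from compound 4, so the absence of that hydrogen does not by itself go with the lower number, and tert-butylamino and pyrrolidin-1-yl have the same count of heavy atoms. Nothing available explains the lower inhibition seen with this ring.

Whether the result belongs to pyrrolidin-1-yl alone or extends to other ring amines stays open, as piperidin-1-yl and morpholin-4-yl are not among the compounds shown. Going by these compounds alone, each compound also has only a single reading at one dose, which gives no measure of potency.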